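The source may report more compounds than this note shows. Statements on the series, on what has been measured and on what is new or still open speak of the compounds shown alone.

Measured compounds:

Compound 1, `COc1ccc(-c2cc3cc(C4C(C#N)=C(N)OC5=C4C(=O)CC(C)(C)C5)cc(C(C)C)c3oc2=O)cc1`, gives 64.9%.
Compound 2, `COc1ccc(-c2cc3cc(C4C(C#N)=C(N)OC5=C4C(=O)CCC5)cc(C(C)C)c3oc2=O)cc1`, gives 69.7%.
Compound 3, `CCC(C)c1cc(C2C(C#N)=C(N)OC3=C2C(=O)CCC3)cc2cc(-c3ccc(OC)cc3)c(=O)oc12`, gives 35.1%.

These three compounds were run in a functional assay on the whole organism (strain Swiss albino) with Mus musculus as the target, in the forced swim test, with a stated time of 5 min, at a dose of 0.5 mg/kg by the intraperitoneal route; on this read-out lower numbers stand for less inhibition and higher numbers for more inhibition at the one dose given (going by the name of the read-out). Compound 2 and compound 1 share much of their structure, but the difference between the two cores is not broken down here; in this assay compound 2 gives 69.7% and compound 1 gives 64.9%, and these two numbers lie within the usual scatter of each other. Compound 3 differs from compound 2 by a single change, (methyl in place of hydrogen on a saturated chain carbon, two bonds along the chain from an aromatic carbon), and this one change is accompanied by a step of a number 34.6 percentage points lower from compound 2 to compound 3 (beyond the scatter).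

Compound 4, `CCC(C)c1cc(C2C(C#N)=C(N)OC3=C2C(=O)CC(C)(C)C3)cc2cc(-c3ccc(OC)cc3)c(=O)oc12`, has not yet been measured. It differs from compound 1 by methyl in place of hydrogen on a saturated chain carbon, two bonds along the chain from an aromatic carbon. The place of this change is described in the same words as the place of the change from compound 2 to compound 3, so it is the same change made on the core of compound 1 instead of the core of compound 2. Among the compounds shown this change occurs only twice, once measured and once not, so the expectation for compound 4 rests on a single observed step. On that basis compound 4 is expected to show a step of about a number 32.9 percentage points lower from compound 1 to compound 4 (beyond the scatter), because the same change gave a number 34.6 percentage points lower from compound 2 to compound 3 (beyond the scatter). Within the data shown here, compound 4 is therefore estimated to give about 32%, with a range from 14% to 52% to allow for the fact that only one earlier instance of this change has been seen.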

Compound 4, a percentage reported as inhibition, in the whole organism at one dose (the size of the read-out at that dose, not a potency): 26.9%
Compound 4: middle estimate off by 5.1 percentage points, on the high side; low and high end bracket the measured number.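

In this assay, the change from isopropyl to sec-butyl on the core of compound 1 is accompanied by a step of a number 38 percentage points lower from compound 1 to compound 4 (beyond the scatter), and set beside the earlier step, the two agree: the same change on two cores in this assay, a number 34.6 percentage points lower (beyond the scatter) from compound 2 to compound 3 and a number 38 percentage points lower (beyond the scatter) from compound 1 to compound 4, 3.4 percentage points apart, within the scatter of two such steps. Within this small set, methyl in place of hydrogen at this place therefore carries over from the core of compound 2 to the core of compound 1, with the same direction and a step of similar size. Among these compounds, this rests on only two matched pairs at a single dose, however, so it does not show that the step would hold on any other core, it does not describe potency, and it does not explain why the number falls.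

The compounds shown carry only isopropyl or sec-butyl at this place, so it remains open how a methyl, a tert-butyl or a cyclohexyl group there would read. The methoxyphenyl group and the nitrile are the same in all four compounds, so it is also unanswered whether the step would persist with, for example, a carboxylic acid in place of the nitrile.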